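The compounds below may be only part of what the source reports. "The series", "measured", "known", "first", "only" and "open" are said of these compounds alone.

Compounds measured in a functional assay on the whole organism (strain Hartley) for inhibition, with Cavia porcellus as the target, with stated times of 15 min and 2 min; on this read-out higher numbers stand for an effect only at larger amounts of compound and lower numbers for an effect already at smaller amounts:
- compound 1, `CCCCC1([C@H](O)/C=C/C2CCC(=O)[C@@H]2CCCCCC(=O)O)CCC1`: 0.032 mg/kg
- compound 2, `CCCCC1([C@H](O)/C=C/C2CCC(=O)[C@@H]2C/C=C\CCCC(=O)O)CCC1`: 0.00767 mg/kg
- compound 3, `CCCCC1([C@@H](O)/C=C/C2[C@H](O)CC(=O)[C@@H]2C/C=C\CCCC(=O)O)CCC1`: 0.305 mg/kg

Among these three values compound 1 stands second highest. Going by the values given here, its nearest neighbour is compound 2, reached by the change a 4.2-fold lower number from compound 1 to compound 2 (0.62 log units; beyond the scatter), and the furthest is compound 3, whose number lies well above that of compound 1; no single-place step links compound 1 and compound 3, so only their two values can be compared.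

Compound 4, `CCCCC1([C@H](O)/C=C/C2CCC(=O)[C@@H]2CCCCSCC(=O)OCC)CCC1`, is not yet measured. It differs from compound 1 in one place: ((ethoxycarbonyl)methyl)sulfanyl in place of carboxymethyl on a saturated chain carbon, four bonds along the chain from a saturated ring carbon. Among the compounds with values here, none of the measured steps touches this part of the molecule; the step from compound 1 to compound 2 concerns the unsaturation of the chain, not its carboxylic end, and compound 3 differs from compound 2 on the ring. The data therefore give no direct guide to the effect of replacing the acid terminus.

Within the data shown here, with no bearing step, compound 4 is expected to sit near compound 1, the estimated step being a 1.9-fold higher number from compound 1 to compound 4 (0.27 log units; within the scatter), within wide bounds. Compound 4 is thus estimated at 0.06 mg/kg in this assay, in the range 0.012 mg/kg to 0.4 mg/kg.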

Compound 4, dose for half-maximal effect: 0.3 mg/kg
Compound 4: the middle estimate sits 5.0-fold (0.70 log units) below what was measured; the measured number falls inside the stated range.
By their numbers in this assay, from the lowest: compound 2; then compound 1; then compounds 4 and 3 (each within the scatter of the next).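

In this assay the chain end proves sensitive: putting ((ethoxycarbonyl)methyl)sulfanyl in place of carboxymethyl gives a 9.4-fold higher number from compound 1 to compound 4 (0.97 log units; beyond the scatter) and so moves the number the opposite way from the chain change in a 4.2-fold lower number from compound 1 to compound 2 (0.62 log units; beyond the scatter) within the same series. Compound 4, whose entering group has no hydrogen-bond donor and no free carboxylic acid, still gives a number of 0.3 mg/kg in this assay, so a free acid at this position is not needed for a measurable effect, though the number is higher with this replacement. Nothing available accounts for the size of this step.

The compounds shown leave open whether the step follows the sulfur in the chain or the ethyl ester. A ((carboxymethyl)sulfanyl) chain end or an ethyl ester on the all-carbon chain of compound 1 would separate these two parts of the change.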